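This account rests on a few compounds, and the source may have more. Where it says the series, first, only, none or still open, it means among the compounds named here.

Measured so far:
compound 1 `COc1ccc(CN(C(=O)Nc2ccc(C#N)cc2)n2cnnc2)cc1OC`: 24100 nM
compound 2 `O=C(Nc1ccccc1)N(Cc1ccccn1)n1cnnc1`: 20200 nM
compound 3 `O=C(NC1CCCCC1)N(Cc1ccccn1)n1cnnc1`: > 50000 nM

In a functional assay on DU-145 cells (Homo sapiens) for cytotoxicity, read by MTT assay, with a stated time of 48 h (a higher number here means a weaker inhibitor, a lower number a stronger inhibitor), compound 1 gives 24100 nM and compound 2 gives 20200 nM, the two numbers lying within the scatter of each other. For compound 3 the value > 50000 nM is a limit of the assay, not a number (the limit of > 50000 nM in this assay, at which 1 of the 3 values shown sits). For the measured compounds named here, the one measured step, an at least 2.4-fold higher number from compound 2 to compound 3 (0.39 log units; beyond the scatter), concerns the group on the amide-type nitrogen and does not bear on the change taken here. Compound 4 `COc1ccc(CN(C(=O)Nc2ccc(C)cc2)n2cnnc2)cc1OC` differs from compound 1 by methyl in place of cyano on an aromatic carbon. Going by the values given here, no measured step covers this change, so no step beyond the scatter is expected in this assay, in either direction. Compound 4 is expected near 28000 nM, between 11000 nM and 70000 nM, the expected step being a 1.2-fold higher number from compound 1 to compound 4 (0.07 log units; within the scatter).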

Compound 4, half-maximal inhibitory concentration: 26300 nM
The estimate for compound 4 lay 1.1-fold (0.03 log units) above the measured number; low and high end bracket the measured number.
By their numbers in this assay, from the lowest: compounds 2, 1 and 4 (each within the scatter of the next). At a limit, above all of these: compound 3.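

In this assay, for the compounds shown here, 4-cyanophenyl to 4-methylphenyl gives a 1.1-fold higher number from compound 1 to compound 4 (0.04 log units; within the scatter), the first reading on this aromatic carbon, since the only earlier step concerned the group on the amide-type nitrogen. On the core of compound 1, nitrile and methyl at this place therefore cannot be told apart in this assay. Nothing shown accounts for this result.

On these data alone, whether an amine or a carboxylic acid on the same aromatic carbon would give a step beyond the scatter remains open. Also open, as far as these compounds go, is whether the same exchange reads alike on the core of compound 2.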